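Notes on removing the ring-amine methyl

A few compounds are considered here, and "the series" means these few. Any claim that something is new, unique, unknown or untested is made for them only; others in the source may bear on it.

Compound 3 `CN1CCC2=CC[C@H](O)C[C@@H]21` in an assay on HEK293 cells for displacement of a labelled ligand from Neuronal acetylcholine receptor; alpha3/beta4 (Rattus norvegicus), with a stated time of 4 h (on this read-out higher numbers stand for weaker inhibition and lower numbers for stronger inhibition), gives only a limit, > 300000 nM. That limit, (the limit of > 300000 nM in this assay, at which 2 of the 3 values shown sit), also holds compound 2 `CO[C@H]1CC=C2CCN[C@H]2C1`: in this assay compound 2 gives > 300000 nM, a limit. For the measured compounds named here, compound 1 `CO[C@H]1CC=C2CCN(C)[C@H]2C1` is the one member with a number; in this assay compound 1 gives 100000 nM. From it, an at least 3.0-fold higher number from compound 1 to compound 2 (0.47 log units; beyond the scatter), and an at least 3.0-fold higher number from compound 1 to compound 3 (0.47 log units; beyond the scatter). Compound 4 `O[C@H]1CC=C2CCN[C@H]2C1` differs from compound 3 by hydrogen in place of methyl on an amine nitrogen in a ring. The same change already moved compound 1 onto the limit, an at least 3.0-fold higher number from compound 1 to compound 2 (0.47 log units; beyond the scatter), so nothing pulls the number down and compound 4 is expected to stay at or past the limit. Compound 4 is expected at 600000 nM, with a range of 300000 nM to 3000000 nM. The expected step is a step that the limit leaves unreadable from compound 3 to compound 4.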

Compound 4, inhibition constant: > 300000 nM
Compound 4 was reported as a limit; the forecaster's own chance of this, stated with the estimate: 90%; the middle value does not contradict the limit.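

No new step can be read from compound 2 or compound 3 to compound 4, as each gives only a limit in this assay: the limit of > 300000 nM in this assay, at which 3 of the 4 values shown sit. The compounds shown leave open how far past that limit these three lie.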